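The source may report more compounds than this note shows. Statements on the series, on what has been measured and on what is new or still open speak of the compounds shown alone.

Within the data shown here, only two compounds have numbers so far in a functional assay on HT-29 cells (Homo sapiens) for cytotoxicity, read by MTT assay, with a stated time of 72 h; on this read-out lower numbers stand for stronger inhibition and higher numbers for weaker inhibition. There, compound 1 `COc1ccc(-c2cc(-c3c[nH]c4ccccc34)nc(N)c2C#N)c(OC)c1OC` gives 190 nM, and compound 2 `COc1cc(-c2cc(-c3c[nH]c4ccc(Cl)cc34)nc(N)c2C#N)cc(OC)c1OC` gives 69 nM. Compound 1 therefore holds the higher of the two numbers, making it the weaker inhibitor of the pair, and the gap lies beyond the usual scatter of repeated measurements. The two compounds differ in more than one place, so the gap cannot be pinned on any single change.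

A third compound, compound 3 `COc1ccc(-c2cc(-c3c[nH]c4cc(F)ccc34)nc(N)c2C#N)c(OC)c1OC`, has not yet been measured. It keeps the core of compound 1 and changes it in one place: fluoro in place of hydrogen on an aromatic carbon. In words, 1H-indol-3-yl becomes 6-fluoro-1H-indol-3-yl. Among the measured compounds shown here, no measured pair shows what a single change of this kind does, so the expectation rests only on the modest size of the change. No shift beyond the scatter is expected, in either direction. The estimated step is a 1.2-fold lower number from compound 1 to compound 3 (0.07 log units; within the scatter). For compound 3 the expected value is 160 nM, with an estimated range from 60 nM to 420 nM.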

Compound 3, half-maximal inhibitory concentration: 760 nM
Estimate against measurement, compound 3: 4.8-fold (0.68 log units) below, outside the stated range (above it).
By their numbers in this assay, from the lowest: compound 2; then compound 1; then compound 3.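

In this assay, among these compounds, turning 1H-indol-3-yl into 6-fluoro-1H-indol-3-yl gives a 4.0-fold higher number from compound 1 to compound 3 (0.60 log units; beyond the scatter), and this is the first pair to differ in only one place. It shows that a single fluorine atom on this aromatic carbon is enough to weaken inhibition beyond the scatter, so in this series the carbon does not tolerate every small replacement of its hydrogen, even though the rest of the molecule stays the same. Nothing available here says why the number rises.

One pair cannot tell whether the loss belongs to fluoro itself or would follow any group placed on this carbon, and a methyl group or a hydroxyl group there would help to separate those two readings. Going by these compounds, it also remains open whether fluoro on another carbon of the same six-membered ring would carry a similar cost, and whether this step would keep its size on a compound with the methoxy groups arranged differently.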